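Swapping one methoxy group on compound 1

This account rests on a few compounds, and the source may have more. Where it says the series, first, only, none or still open, it means among the compounds named here.

Values in a functional assay on MCF7 cells (Homo sapiens) for antiproliferative activity, read by MTT assay, with stated times of 24 h and 72 h (a lower number here means a stronger inhibitor, a higher number a weaker inhibitor), for the measured compounds:
- compound 1 `COc1ccc([C@@H]2[C@H](Oc3ccccc3)C(=O)N2c2cc(OC)c(OC)c(OC)c2)cc1OC` gives 26000 nM
- compound 2 `COc1cc([C@@H]2[C@H](Oc3ccccc3)C(=O)N2c2cc(OC)c(OC)c(OC)c2)ccc1O` gives 32000 nM
- compound 3 `COc1cc([N+](=O)[O-])c([C@@H]2[C@H](Oc3ccccc3)C(=O)N2c2cc(OC)c(OC)c(OC)c2)cc1O` gives 59000 nM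

Compound 1 stands at the lower end of these three numbers. Compound 4 `COc1ccc([C@@H]2[C@H](Oc3ccccc3)C(=O)N2c2cc(OC)c(OC)c(OC)c2)cc1NC(=O)CN` keeps the core of compound 1 but carries ((aminomethyl)carbonyl)amino in place of methoxy on an aromatic carbon. Within the data shown here, no measured step makes this swap. The nearest evidence is two changes to the same aromatic ring, a 1.2-fold higher number from compound 1 to compound 2 (0.09 log units; within the scatter) and a 2.3-fold higher number from compound 1 to compound 3 (0.36 log units; beyond the scatter). Both were small, so no clear step is expected in this assay in either direction, although the range stays wide for this untested group. The estimated step is a 1.2-fold higher number from compound 1 to compound 4 (0.06 log units; within the scatter). The expected value for compound 4 is 30000 nM, within an estimated range of 8000 nM to 90000 nM.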

Compound 4, half-maximal inhibitory concentration: 6500 nM
Beside the measured number, compound 4's estimate is 4.6-fold (0.66 log units) above it; measured number outside the range, below it.
By their numbers in this assay, from the lowest: compound 4; then compounds 1, 2 and 3 (each within the scatter of the next, the first and the last beyond it).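

With ((aminomethyl)carbonyl)amino in place of methoxy, this assay gives a 4.0-fold lower number from compound 1 to compound 4 (0.60 log units; beyond the scatter). This shows that this aromatic carbon tolerates a larger group, and that a change on this ring can lower the number beyond the scatter, which neither earlier change did: they gave a 1.2-fold higher number from compound 1 to compound 2 (0.09 log units; within the scatter) and a 2.3-fold higher number from compound 1 to compound 3 (0.36 log units; beyond the scatter). Nothing measured here accounts for the drop. Going by these compounds, it remains open which part of the new group matters. A plain amine, an acetylamino group or a longer chain ending in an amine on this carbon could separate those parts.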